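This account rests on a few compounds, and the source may have more. Where it says the series, first, only, none or still open, it means among the compounds named here.

Three compounds share one core and differ only in the aromatic group sitting on a double-bonded chain carbon bound to a double-bonded ring carbon. Compound 1 `CCOC(=O)C1=C(Nc2ccccc2)S/C(=C\c2ccc(Br)c(O)c2)C1=O` carries a 4-bromo-3-hydroxyphenyl there, and in a functional assay on MCF7 cells (Homo sapiens) for inhibition, read by MTT assay, with a stated time of 72 h, tested at 10 uM (a higher number here means more inhibition at the concentration tested (going by the name of the read-out), a lower number less inhibition), compound 1 gives 16.4%. Compound 2 `CCOC(=O)C1=C(Nc2ccccc2)S/C(=C\c2ccc(C(=O)O)cc2)C1=O` carries a 4-carboxyphenyl. In this assay compound 2 reaches only a limit of the assay, < 10%, not a number. Compound 3 `CCOC(=O)C1=C(Nc2ccccc2)S/C(=C\c2cccc(C(=O)O)c2)C1=O` carries a 3-carboxyphenyl. In this assay compound 3 also stands at a limit, < 10%, so its reading is known only as a limit. The measured steps are a number at least 6.4 percentage points lower from compound 1 to compound 2 (that floor lies within the scatter) and a number at least 6.4 percentage points lower from compound 1 to compound 3 (that floor lies within the scatter), both within the usual scatter, and a step that the two limits leave unreadable from compound 2 to compound 3; the picture is shaped by the limit of < 10% in this assay, at which 2 of the 3 values shown sit. Compound 4 `CCOC(=O)C1=C(Nc2ccccc2)S/C(=C\c2ccc[nH]2)C1=O` differs from compound 3 as follows: 1H-pyrrol-2-yl in place of 3-carboxyphenyl on a double-bonded chain carbon bound to a double-bonded ring carbon. Within the data shown here, none of the measured steps covers a 1H-pyrrol-2-yl, so the expectation rests only on the low readings of all three measured compounds. Compound 4 is expected to give 12%, in a range from 5% to 25%, which means an expected step of a number at least 2 percentage points higher from compound 3 to compound 4 (that floor lies within the scatter) and a fair chance of only another limit.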

Compound 4, a percentage reported as inhibition, at one concentration (the size of the read-out at that concentration, not a potency): 18.3%
For compound 4 the middle estimate is 6.3 percentage points below the measured one; low and high end bracket the measured number.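

The step to 1H-pyrrol-2-yl gives a number at least 8.3 percentage points higher from compound 3 to compound 4 (that floor lies within the scatter) and a number at least 8.3 percentage points higher from compound 2 to compound 4 (that floor lies within the scatter), so a group without a carboxylic acid at this place again gives a number rather than a limit. Compared with the only other numeric reading, the step is a number 1.9 percentage points higher from compound 1 to compound 4 (within the scatter), so 1H-pyrrol-2-yl and 4-bromo-3-hydroxyphenyl read alike in this assay, although they share neither ring size nor atoms beyond carbon and hydrogen. The steps out of compound 2 and compound 3 remain floors, and the step between those two cannot be read, because the true readings of both lie hidden at the limit: the limit of < 10% in this assay, at which 2 of the 4 values shown sit.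

As far as these compounds go, whether any group at this place can lift the reading clear of the scatter stays open. So does whether a furan-2-yl, or a phenyl ring carrying an amine, would read like compound 4 or like compound 2.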